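Swapping 2-Chlorobenzyl for 3-Chlorobenzyl on Two Cores

This account rests on a few compounds, and the source may have more. Where it says the series, first, only, none or still open, it means among the compounds named here.

In a functional assay on the whole organism (artery, strain albino) with Rattus norvegicus as the target, with a stated time of 30 min, at a dose of 10 mg/kg by the oral route (a higher number here means more inhibition at the dose given (going by the name of the read-out), a lower number less inhibition), the three measured compounds gave the following:

compound 1, `COc1ccc(C2N=C(SCc3ccccc3Cl)NC(C)=C2C(=O)Nc2ccc(F)cc2)cc1OC`: 6.2%
compound 2, `COc1ccc(C2N=C(SCc3cccc(Cl)c3)NC(C)=C2C(=O)Nc2ccc(F)cc2)cc1OC`: 5.2%
compound 3, `CC1=C(C(=O)Nc2ccc([N+](=O)[O-])cc2)C(c2ccc(Br)cc2)N=C(SCc2ccccc2Cl)N1`: 3.6%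

Compound 1 and compound 2 share one core and differ in a single place, (3-chlorophenyl in place of 2-chlorophenyl on a saturated chain carbon bound to a sulfur). This change produced a number 1 percentage points lower from compound 1 to compound 2 (within the scatter), so the two values say nothing about an order between them.

Compound 3 carries a different core; the difference between the core of compound 1 and the core of compound 3 is not broken down here. Its value in this assay is the lowest of the three numbers, but its steps to compound 2 and to compound 1 are both within the scatter, so the three numbers can only be called level with one another.

Compound 4, `CC1=C(C(=O)Nc2ccc([N+](=O)[O-])cc2)C(c2ccc(Br)cc2)N=C(SCc2cccc(Cl)c2)N1`, has not been measured. It differs from compound 3 by 3-chlorophenyl in place of 2-chlorophenyl on a saturated chain carbon bound to a sulfur. The place of this change is described in the same words as the change from compound 1 to compound 2, so it is the same change, made on the core of compound 3 instead of the core of compound 1.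

For compound 4 the step of a number 1 percentage points lower from compound 3 to compound 4 (within the scatter) is expected to be small, because the same change gave a number 1 percentage points lower from compound 1 to compound 2 (within the scatter) and because compound 3 itself sits at 3.6%, leaving little room for a drop. The estimate for compound 4 in this assay is 2.6%, with a likely range from -5% to 10%.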

Compound 4, a percentage reported as inhibition, in the whole organism at one dose (the size of the read-out at that dose, not a potency): 2.6%
Beside the measured number, compound 4's estimate shows no gap at the digits printed; low and high end bracket the measured number.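

Replacing 2-chlorobenzyl with 3-chlorobenzyl on the core of compound 3 gave, in this assay, a number 1 percentage points lower from compound 3 to compound 4 (within the scatter). Set beside the same change on the core of compound 1, the two steps agree: the same change on two cores in this assay, a number 1 percentage points lower (within the scatter) from compound 1 to compound 2 and a number 1 percentage points lower (within the scatter) from compound 3 to compound 4, 0 percentage points apart, within the scatter of two such steps

For the compounds shown here, both steps lie within the scatter, so the agreement shows only that this change made no readable difference on either of these two cores; it does not show that a step of real size would carry from one core to the other, and two cores say nothing about any further core.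

All the compounds shown carry a chlorobenzyl group on the sulfur, which leaves open what a benzyl group without chlorine, a methyl group or a longer alkyl chain in that place would give in this assay. Also open, going by these compounds, is whether an amine or a carboxylic acid in place of the chlorine would give a step beyond the scatter on either core.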